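Exchanging the Carboxyl Chain of Compound 3

A few compounds are considered here, and "the series" means these few. Any claim that something is new, unique, unknown or untested is made for them only; others in the source may bear on it.

Of the compounds shown here, three have so far been measured in a functional assay on NCI-H441 cells (Homo sapiens) for antiproliferative activity, with a stated time of 24 h (a higher number here means a weaker inhibitor, a lower number a stronger inhibitor), on this series. Compound 1 (`CN(C)c1ccc(/C=C2\CNC/C(=C\c3ccc(N(C)C)cc3)C2=O)cc1`) gives 101000 nM there, and compound 2 (`OC1/C(=C/c2ccccc2F)CNC/C1=C\c1ccccc1F`) gives 124000 nM there. Compound 3 (`O=C(O)/C=C/C(=O)N1C/C(=C\c2ccccc2F)C(=O)/C(=C/c2ccccc2F)C1`) gives 29000 nM and so stands lowest of the three, with its gap to each of the other two lying beyond the usual scatter of repeated measurements.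

The next compound to be measured, compound 4 (`O=C(O)CCCC(=O)N1C/C(=C\c2ccccc2F)C(=O)/C(=C/c2ccccc2F)C1`), differs from compound 3 in one place. It carries 3-carboxypropyl in place of 2-carboxyethenyl on a carbonyl carbon. Going by the values given here, no measured pair isolates this change, so the data give no direct size for it. Among the compounds with values here, the only close reference is compound 3 at 29000 nM in this assay and the expectation is built on that value alone. A small move toward a higher number, meaning a slightly weaker inhibitor, is expected, and it should not go beyond the scatter. The expected change is a 1.3-fold higher number from compound 3 to compound 4 (0.12 log units; within the scatter) on this reasoning. For compound 4 the estimated value is 38000 nM with an expected range from 16000 nM to 85000 nM once it is measured.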

Compound 4, half-maximal inhibitory concentration: 60000 nM
For compound 4 the middle estimate is 1.6-fold (0.20 log units) below the measured one; the range from low to high includes it.
By their numbers in this assay, from the lowest: compound 3; then compounds 4, 1 and 2 (each within the scatter of the next, the first and the last beyond it).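

In this assay, the exchange of 2-carboxyethenyl for 3-carboxypropyl on a carbonyl carbon gives a 2.1-fold higher number from compound 3 to compound 4 (0.32 log units; beyond the scatter), the first step measured at this position, and it shows that the position responds to the make-up of the chain even when the carboxylic acid end is kept and the hydrogen-bond donor and acceptor counts stay the same. The step is modest, but it shows that the chain cannot be exchanged here without a measurable loss, and it couples two differences, since 3-carboxypropyl has one more heavy atom and one double bond fewer than 2-carboxyethenyl. No available evidence accounts for the step, so the result stands as an observation without an explanation.

The compounds shown do not separate those two differences: 2-carboxyethyl, a saturated chain shorter than 3-carboxypropyl, would be needed to tell whether the double bond or the chain length goes with the step. Also open, on these data alone, is whether the carboxylic acid itself matters at this position, a question that an amine at the chain end, a methyl ester or a longer chain could address.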